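Furan-2-yl to furan-3-yl on compound 3

The source may report more compounds than this note shows. Statements on the series, on what has been measured and on what is new or still open speak of the compounds shown alone.

Compound 1 (`CSc1ncnc2c1c(-c1ccoc1)cn2[C@@H]1O[C@H](CO)[C@@H](O)[C@H]1O`) gives (98800 nM)
Compound 2 (`CSc1ncnc2c1c(-c1ccccc1)cn2[C@@H]1O[C@H](CO)[C@@H](O)[C@H]1O`) gives (> 100000 nM), a limit
Compound 3 (`CNc1ncnc2c1c(-c1ccco1)cn2[C@@H]1O[C@H](CO)[C@@H](O)[C@H]1O`) gives (5040 nM)
Compound 4 (`CNc1ncnc2c1c(-c1ccoc1)cn2[C@@H]1O[C@H](CO)[C@@H](O)[C@H]1O`) is not yet measured

All three values come from an ADME assay on BJ cells (Homo sapiens), read by MTT assay, with a stated time of 72 h (a higher number here means a weaker inhibitor, a lower number a stronger inhibitor), and are read as half-maximal inhibitory concentrations. Compound 3 holds the lowest of the numbers shown (5040 nM). Its nearest neighbour is compound 1 (98800 nM), whose number is higher, and the gap between the two lies beyond the scatter. Compound 2 stands at a limit of the assay (> 100000 nM), so it gives no number.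

The next step keeps the atoms of compound 3 and joins them differently (furan-3-yl in place of furan-2-yl on an aromatic carbon): furan-3-yl in place of furan-2-yl on an aromatic carbon. Among the measured compounds shown here, no measured step exchanges one furan for the other. For the measured compounds named here, the only measured step at this carbon is phenyl in place of furan-3-yl (an at least 1.0-fold higher number from compound 1 to compound 2 (0.00 log units; that floor lies within the scatter)), and this floor lies within the scatter. It is weak guidance, since it rests on a limit and involves a different exchange. On that basis, no step beyond the scatter is expected in this assay in either direction, although the range is kept wide. The expected step is small (a 1.2-fold higher number from compound 3 to compound 4 (0.08 log units; within the scatter)). The estimated value for compound 4 is (6000 nM), with an expected range (1800 nM to 20000 nM).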

Compound 4, half-maximal inhibitory concentration: 96300 nM
For compound 4 the middle estimate is 16-fold (1.21 log units) below the measured one; measured number above the stated range.
By their numbers in this assay, from the lowest: compound 3; then compounds 4 and 1 (each within the scatter of the next). At a limit, above all of these: compound 2.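

In this assay, the point of attachment of the furan on this aromatic carbon proves decisive for compound 3: with the atoms unchanged, the exchange gives a 19-fold higher number from compound 3 to compound 4 (1.28 log units; beyond the scatter), something the earlier step from furan-3-yl to phenyl, resting on a limit, could not show. With furan-3-yl held constant, methylamino in place of methylsulfanyl gives a 1.0-fold lower number from compound 1 to compound 4 (0.01 log units; within the scatter), so among the compounds shown this exchange makes no difference that can be read while furan-3-yl is present. This flat step should be read with care, since compound 1 and compound 4 both lie close to the top of the range, where compound 2 stands at a limit and gives no number: the limit of > 100000 nM in this assay, at which 1 of the 4 values shown sits.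

As far as these compounds go, it remains open whether furan-2-yl gives a similarly low number with methylsulfanyl on the core, or whether the low number of compound 3 needs furan-2-yl and methylamino together. Also open, from the compounds shown here alone, is how the series responds at this carbon to thiophen-2-yl in place of furan-2-yl, and at the methylamino position to dimethylamino.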